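The source may hold more compounds than are shown below. What is called first, only, known or untested is meant among the compounds shown, and "the series" means these compounds.

Measured compounds:
- Compound 1 `CCOC(=O)C1(O)CC(c2ccc(Cl)cc2)C2=C(CC(C)(C)CC2=O)O1`: "not active" (no number reported) in an assay on isolated protein for inhibition of glucose-6-phosphatase catalytic subunit 1 (Homo sapiens), read by inositol phosphate accumulation, with a stated time of 30 min, tested at 100 uM; a higher number here means more inhibition at the concentration tested (going by the name of the read-out), a lower number less inhibition
- Compound 2 `CC1(C)CC(=O)C2=C(C1)NC(C(=O)O)=CC2c1ccccc1`: 17.1%
- Compound 3 `CCOC(=O)C1(O)CC(c2ccc(OC)cc2)C2=C(CC(C)(C)CC2=O)O1`: "not active" (no number reported)

Compound 3 stands with no number at all: the outcome for compound 3 is simply reported as "not active", and compound 1, which shares the same core, is reported the same way. Only compound 2, built on a different core, has a figure, and compound 2 gives 17.1% in this assay, a modest percentage.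

Compound 4 `CCOC(=O)C1(O)CC(c2ccc(F)cc2)C2=C(CC(C)(C)CC2=O)O1` is the next member of the shared core, still to be measured. Compared with compound 3, the change is fluoro in place of methoxy on an aromatic carbon. For the measured compounds named here, no measured pair here shows what such a swap does, so there is no step to lean on. Given that compound 3 and compound 1 both returned no number, the expectation is that the change from compound 3 to compound 4 brings no shift beyond the scatter of this assay, and most likely the same "not active" report.

If a number does appear, compound 4 is estimated at 5%, with a range from 0% to 20%.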

Compound 4, a percentage reported as inhibition, at one concentration (the size of the read-out at that concentration, not a potency): "not active" (no number reported)
No number was reported for compound 4; no gap can be computed for the estimate.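

Compound 3 and compound 4 are both reported as "not active" with no number, so no step can be read between them. Nothing measured here bears on this result. The compounds shown leave open whether any change on their shared core gives a measurable inhibition.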